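Branched alkyl in place of the aminoethyl chain on compound 1

The source may report more compounds than this note shows. Statements on the series, on what has been measured and on what is new or still open speak of the compounds shown alone.

Of the compounds shown here, two have numbers so far. In a functional assay on ileum for inhibition of histamine H1 receptor (Cavia porcellus) (on this read-out lower numbers stand for stronger inhibition and higher numbers for weaker inhibition), compound 1 `CCNCCn1c(N2CCN(C)CC2)nc2ccccc21` gives 290 nM, and compound 2 `CN1CCCN(c2nc3ccccc3n2CCOc2ccccc2)CC1` gives 9.1 nM. Compound 1 thus stands with the highest of the two numbers; its nearest neighbour is compound 2, whose number is lower by a gap beyond the scatter. The two differ in more than one place, so the gap is not assigned to any single change.

Compound 3 `CCCC(C)n1c(N2CCN(C)CC2)nc2ccccc21` is not yet measured. It differs from compound 1 in one place: 1-methylbutyl in place of 2-(ethylamino)ethyl on an aromatic nitrogen. The group that leaves carries a hydrogen-bond donor and an acceptor; the group that enters carries neither.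

Among the compounds with values here, no step between measured compounds isolates this change, so the expectation rests on the two numbers only. The number for compound 2 shows that a substituent without a basic nitrogen on this ring nitrogen is compatible with strong inhibition, which argues against a large loss. The step from compound 1 to compound 3 is therefore expected to be a 1.9-fold lower number from compound 1 to compound 3 (0.29 log units; within the scatter), a modest gain that may still fall inside the scatter. Compound 3 is estimated at 150 nM in this assay, with a range from 40 nM to 600 nM.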

Compound 3, half-maximal inhibitory concentration: 1400 nM
Compound 3: middle estimate off by 9.3-fold (0.97 log units), on the low side; the measured number lies above the stated range.
By their numbers in this assay, from the lowest: compound 2; then compound 1; then compound 3.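

On the core of compound 1, with the 4-methylpiperazin-1-yl group unchanged, 1-methylbutyl in place of 2-(ethylamino)ethyl on the aromatic nitrogen gives a 4.8-fold higher number from compound 1 to compound 3 (0.68 log units; beyond the scatter) in this assay, so at this position the chain carrying the nitrogen is the better of the two groups on this read-out. Within the data shown here, this is the first step that isolates a change at this position, and it holds the count of 5 heavy atoms constant while the entering group has no hydrogen-bond donor or acceptor and is branched at the carbon on the ring nitrogen. Which of these differences accounts for the step cannot be told, as nothing at hand bears on a cause.

The compounds shown leave open whether the nitrogen of the chain or the branching of the entering group matters more, a question that an unbranched pentyl chain or a 2-methoxyethyl chain on the same core would help to separate. Also open, as far as these compounds go, is how a tertiary amine such as 2-(diethylamino)ethyl would stand at this position.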